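Chain extension on the ring nitrogen of a thiophene-fused urea

This account rests on a few compounds, and the source may have more. Where it says the series, first, only, none or still open, it means among the compounds named here.

Compound 1 `CC(C)CN1CCc2c(sc(NC(=O)Nc3ccc(Cl)cc3)c2C(N)=O)C1` is assessed in a functional assay (strain AB) with Danio rerio as the target, read by microscopy, with a stated time of 1 h (a lower number here means that less compound is needed, a higher number that more compound is needed for the effect), where compound 1 gives 4510 nM. Among the three measured compounds this is the highest number. Compound 2 `CCN1Cc2sc(NC(=O)Nc3ccc(Cl)cc3)c(C(N)=O)c2C1` gives 4340 nM in this assay, a value that lies within the scatter of the number for compound 1, so the two cannot be ranked. Compound 3 `C[N+]1(CC2CCC2)CCc2c(sc(NC(=O)Nc3ccc(Cl)cc3)c2C(N)=O)C1` gives 210 nM, a number well beyond the scatter and far lower than that of compound 1; compound 3 carries a quaternary nitrogen, which the other two lack.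

Compound 4 `CC(C)(C)OC(=O)CCCCN1CCc2c(sc(NC(=O)Nc3ccc(Cl)cc3)c2C(N)=O)C1` is not yet measured. It differs from compound 1 in one place: 3-(tert-butoxycarbonyl)propyl in place of isopropyl on a saturated chain carbon bound to an amine nitrogen in a ring. Among the measured compounds shown here, no measured pair shows a change of this kind on the same position, so the record gives no direct guide. The neutral ring nitrogen of compound 1 is kept, and compounds 1 and 2 suggest that variation at this site leaves the number roughly where it is. The step of a 1.4-fold lower number from compound 1 to compound 4 (0.15 log units; within the scatter) is therefore expected to stay within the scatter, with at most a slight drift to a lower number. For compound 4 the value in this assay is estimated at 3200 nM, within a range from 1100 nM to 9500 nM.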

Compound 4, half-maximal effective concentration: 710 nM
Beside the measured number, compound 4's estimate is 4.5-fold (0.65 log units) above it; measured number outside the range, below it.
By their numbers in this assay, from the lowest: compound 3; then compound 4; then compounds 2 and 1 (each within the scatter of the next).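

In this assay, among the compounds shown here, putting 3-(tert-butoxycarbonyl)propyl in place of isopropyl gives a 6.4-fold lower number from compound 1 to compound 4 (0.80 log units; beyond the scatter), the first measured step at this site to lie beyond the scatter. It shows that a change on the saturated chain carbon bound to the amine nitrogen in the ring can move the number, with no net charge added by the entering group; compounds 1 and 2 differ in more than one place and could not show this. Nothing measured here accounts for the step.

The step brings in the longer chain and the tert-butyl ester together, so the compounds shown leave open which of the two matters. A plain alkyl chain of the same length, or a carboxylic acid in place of the ester, would separate them.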